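This account rests on a few compounds, and the source may have more. Where it says the series, first, only, none or still open, it means among the compounds named here.

Series notes. Going by the values given here, in a physicochemical assay for solubility, in phosphate buffer, measured as kinetic solubility, with a stated time of 1 h, at pH 7.4 (on this read-out lower numbers stand for lower solubility and higher numbers for higher solubility), compound 2 `COc1ccc2nc(C)cc(OCC(=O)Nc3ccccn3)c2c1` gives 29000 nM, the highest of the two numbers so far; the nearest is compound 1 `COc1ccc2nc(C)cc(OCC(=O)Nc3cc(F)cc(F)c3)c2c1`, which in this assay gives 13000 nM. Among the compounds with values here, the single step measured to date is a 2.2-fold higher number from compound 1 to compound 2 (0.35 log units; beyond the scatter), a modest move upward that arose from swapping the group on the amide-type nitrogen. Compound 3 `COc1ccc2nc(C)cc(OCC(=O)NC3CONC3=O)c2c1` is still to be measured; it differs from compound 2 as follows: a group of 6 heavy atoms (3 carbon, 1 nitrogen, 2 oxygen; one five-membered non-aromatic ring with 2 hetero atoms) in place of a group of 6 heavy atoms (5 carbon, 1 nitrogen; one six-membered aromatic ring with 1 hetero atom), on an amide-type nitrogen. The step from compound 1 to compound 2 is the only one that bears on this change, since it touches the same position, and it was modest. Within the data shown here, with no second example of this position in hand, a rise beyond the scatter, of a size near to or somewhat larger than that step, is the expectation rather than a firm call. Compound 3 is therefore estimated at 60000 nM, within 25000 nM to 150000 nM, which means an expected step of a 2.1-fold higher number from compound 2 to compound 3 (0.32 log units; beyond the scatter).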

Compound 3, solubility: >= 166000 nM
Compound 3 gave a limit, no number (the forecaster's own chance of this, stated with the estimate: 15%); at least 2.7-fold (0.44 log units) between middle value and limit.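

In this assay, compound 3 reads as a limit of the assay and not as a number: the limit of >= 166000 nM in this assay, at which 1 of the 3 values shown sits. Replacing pyridin-2-yl on the amide-type nitrogen with the five-membered non-aromatic ring is an at least 5.7-fold higher number from compound 2 to compound 3 (0.75 log units; beyond the scatter), and replacing 3,5-difluorophenyl with the same ring is an at least 12-fold higher number from compound 1 to compound 3 (1.10 log units; beyond the scatter). Previously this position had shown only a 2.2-fold higher number from compound 1 to compound 2 (0.35 log units; beyond the scatter), so it now spans a wider range, and an aromatic ring on this nitrogen is no longer the only case seen, though the upper end of the range remains unfixed.

The entering ring differs from pyridin-2-yl in ring size, aromatic character and hydrogen-bond donors all at once, and the compounds shown do not separate these features. On these data alone, it also remains open where a simple amine, a carboxylic acid or a longer chain on this nitrogen would fall relative to the limit of compound 3.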